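A few compounds are considered here, and "the series" means these few. Any claim that something is new, unique, unknown or untested is made for them only; others in the source may bear on it.

Compound 1 `COc1cccc(/C=C/C(=O)c2sc(Nc3ccccc3)nc2C)c1` sits at the limit of a functional assay on PC-3 cells (Homo sapiens) for cytotoxicity, read by MTT assay (on this read-out higher numbers stand for weaker inhibition and lower numbers for stronger inhibition), giving > 25000 nM. Compound 2 `Cc1nc(Nc2ccccc2)sc1C(=O)/C=C/c1ccc(Cl)cc1` likewise gives only the limit > 25000 nM in this assay. Compound 3 `Cc1nc(Nc2ccc(Cl)c(Cl)c2)sc1C(=O)/C=C/c1ccccc1` gives 7990 nM in this assay. The step is a step that the two limits leave unreadable from compound 1 to compound 2. Compound 4 `Cc1nc(Nc2cccc(Cl)c2)sc1C(=O)/C=C/c1ccc(Cl)cc1` differs from compound 2 by chloro in place of hydrogen on an aromatic carbon, the chloro entering on an aromatic carbon of a six-membered aromatic ring of carbon only, meta to a large group. Among the compounds with values here, no measured step alters the anilino ring alone, and compound 3 differs from compound 2 in two places, so only their values are known. Because two of the three values sit at the limit of > 25000 nM in this assay, at which 2 of the 3 values shown sit, no size can be read for the present change. Compound 4 is estimated at 12000 nM, between 4000 nM and 40000 nM. The expected step is an at least 2.0-fold lower number from compound 2 to compound 4 (0.31 log units; beyond the scatter), though a limit may again be reported.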

Compound 4, half-maximal inhibitory concentration: > 25000 nM
Compound 4 gave a limit, no number (the forecaster's own chance of this, stated with the estimate: 45%); middle value at least 2.0-fold (0.31 log units) from the limit.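

Compound 4, like compound 2, stays at a limit, so no step between the two can be read: the limit of > 25000 nM in this assay, at which 3 of the 4 values shown sit.

The compounds shown leave open what chloro in place of hydrogen on this aromatic carbon does in this assay.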